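Replacing the sulfanyl side chain of compound 2

The compounds below may be only part of what the source reports. "The series", "measured", "known", "first", "only" and "open" are said of these compounds alone.

Measured in an in vitro ADME assay on microsomes (Homo sapiens) for metabolic stability; a lower number here means that the compound disappears faster, a higher number that the compound lasts longer:
- compound 1 `CCc1nc(-c2ccc(Cl)cc2Cl)c(CC)nc1NC(COC)COC`: 0.15 h
- compound 2 `CCc1nc(-c2ccc(Cl)cc2Cl)c(CC)nc1SC(C)CC`: 0.283 h

In this assay compound 2 stands at 0.283 h, within the scatter of compound 1. In compound 3 `CCCN(CC1CC1)c1nc(CC)c(-c2ccc(Cl)cc2Cl)nc1CC`, (cyclopropylmethyl)(propyl)amino takes the place of (sec-butyl)sulfanyl on an aromatic carbon ((cyclopropylmethyl)(propyl)amino in place of (sec-butyl)sulfanyl on an aromatic carbon). Among the measured compounds shown here, the only measured step at this place, a 1.9-fold higher number from compound 1 to compound 2 (0.28 log units; within the scatter), is the sole guide, and it does not leave the scatter. No change beyond the scatter is therefore expected in this assay, and the estimated step is a 1.3-fold lower number from compound 2 to compound 3 (0.11 log units; within the scatter). For compound 3 the expected half-life is 0.22 h, with an estimated range of 0.09 h to 0.5 h.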

Compound 3, half-life: 0.2 h
Compound 3: the middle estimate sits 1.1-fold (0.04 log units) above what was measured, and the stated range covers the measured number.
By their numbers in this assay, from the lowest: compounds 1, 3 and 2 (each within the scatter of the next).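

In this assay this position shows a 1.4-fold lower number from compound 2 to compound 3 (0.15 log units; within the scatter) and a 1.3-fold higher number from compound 1 to compound 3 (0.12 log units; within the scatter), so (cyclopropylmethyl)(propyl)amino, with its three-membered ring of carbon only, gives no step beyond the scatter from either (sec-butyl)sulfanyl or (2-methoxy-1-(methoxymethyl)ethyl)amino. Sulfur-linked and nitrogen-linked groups at this place, on the shared core, therefore remain within the scatter of one another in these compounds. No measurement at hand explains this result.

Going by these compounds, whether a carboxylic acid or a primary amine at this place would move the half-life beyond the scatter stays open. Also open, on these data alone, is the effect of a longer chain in place of either ethyl group.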